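The compounds below may be only part of what the source reports. "The series", "measured", "known", "first", "only" and "open" are said of these compounds alone.

Working notes on the series. Among the measured compounds shown here, compound 1 `C[C@H]1C(=O)N(C)C=Cc2cc(CCO)ccc21` is the first measured member; in a physicochemical assay for solubility (on this read-out higher numbers stand for higher solubility and lower numbers for lower solubility), compound 1 gives a limit of the assay, >= 108 ug/mL. Compound 2 `C[C@H]1C(=O)N(C)C=Cc2cc(C(O)CO)ccc21` differs from compound 1 by hydroxy in place of hydrogen on a saturated chain carbon bound to an aromatic carbon and a saturated chain carbon; in this assay compound 2 also gives only a limit, >= 101 ug/mL. The step that the two limits leave unreadable from compound 1 to compound 2 is thus not readable. Compound 3 `CCOc1ccc2c(c1)C(c1c[nH]c(C)n1)=CN(C)C(=O)[C@@H]2C` has a different core, and the difference between the two cores is not broken down here; in this assay compound 3 gives a limit, >= 135 ug/mL. Compound 4 `Cc1nc(C2=CN(C)C(=O)[C@H](C)c3ccc(OCCO)cc32)c[nH]1` differs from compound 3 by hydroxy in place of hydrogen on a saturated chain carbon, two bonds along the chain from an oxygen on an aromatic ring. This is the same kind of change as from compound 1 to compound 2, though the place differs: there the carbon was bound to an aromatic carbon and a saturated chain carbon, here it lies two bonds along the chain from an oxygen on an aromatic ring. The earlier step gave no readable size. The step of a number no higher from compound 3 to compound 4 (the limit leaves the size open) is expected to be small, resting on compound 3 standing at the limit of >= 135 ug/mL in this assay, at which 1 of the 3 values shown sits. Compound 4 is expected to give about 135 ug/mL in this assay, most likely again as a limit.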

Compound 4, solubility: >= 185 ug/mL
Compound 4 gave a limit, no number; the forecaster's own chance of this, stated with the estimate: 80%; middle value at least 1.3-fold (0.13 log units) away from the limit.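

In this assay compound 3 gives only a limit of >= 135 ug/mL and no number. Compound 4 also gives only a limit of >= 185 ug/mL and no number, so the step between compound 3 and compound 4 cannot be read. The compounds shown leave open the size of the change on placing hydroxy in place of hydrogen, in this pair and between compound 1 and compound 2.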